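The source may report more compounds than this note shows. Statements on the series, on what has been measured and on what is new or still open speak of the compounds shown alone.

Within the data shown here, in an ADME assay (liver) for metabolic stability, with Liver microsome (Rattus norvegicus) as the target, read by LC-MS, using microsomes and NADPH, with stated times of 5 min and 60 min, tested at 4 uM (a higher number here means that more of the compound is left, a lower number that less of the compound is left), compound 3 (`CCC(=O)c1ccc(OCCCCOc2ccc(F)c(C(=O)O)c2)c(C)c1O`) gives 35% and holds the lowest of the three numbers so far. Compound 2 (`Cc1c(OCCCCOc2ccc(F)c(C(=O)O)c2)ccc(C(=O)CC(C)(C)C)c1O`) gives 58% and compound 1 (`Cc1c(OCCCCOc2ccc(C(=O)O)cc2F)ccc(C(=O)CC2CCCC2)c1O`) gives 66% in the same test. Compound 4 (`Cc1c(OCCCCOc2ccc(F)c(C(=O)O)c2)ccc(C(=O)C(C)C)c1O`) differs from compound 3 in one place (methyl in place of hydrogen on a saturated chain carbon bound to a carbonyl carbon and a saturated chain carbon) where a methyl takes the place of a hydrogen on a saturated chain carbon bound to a carbonyl carbon and a saturated chain carbon, so that ethyl becomes isopropyl. Among the measured compounds shown here, the one measured step that bears on this swaps tert-butyl for methyl on a saturated chain carbon bound to a carbonyl carbon (a number 23 percentage points lower from compound 2 to compound 3 (beyond the scatter)) and it runs the opposite way, with the larger group leaving. The single methyl added here is far smaller than that tert-butyl. Only part of that gap is therefore expected to return, so the estimated step is a small rise (a number 11 percentage points higher from compound 3 to compound 4 (beyond the scatter)). This rests on one pair of compounds alone. Compound 4 is expected to give 46% (32% to 60%).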

Compound 4, percent of the compound remaining: 60%
Estimate against measurement, compound 4: 14 percentage points below; the measured number falls inside the stated range.
By their numbers in this assay, from the lowest: compound 3; then compounds 2, 4 and 1 (each within the scatter of the next).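

In this assay the change from ethyl to isopropyl gives a number 25 percentage points higher from compound 3 to compound 4 (beyond the scatter) and shows that one methyl on this saturated chain carbon is enough to move the number beyond the scatter. Putting isopropyl in place of neopentyl on the carbonyl carbon gives a number 2 percentage points higher from compound 2 to compound 4 (within the scatter) and shows that, among these compounds, the additional carbons of neopentyl bring no measurable difference over isopropyl. No measurement at hand explains why this single methyl has such an effect.

On these data alone, whether a cyclopropyl ring or a hydroxyl group on this same carbon would give a similar number remains open. As far as these compounds go, it also remains open whether isopropyl would behave the same way on the core of compound 1, where the fluorine and carboxylic acid are arranged differently.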